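Swapping 4-chlorobenzyl for 3-bromobenzyl

This account rests on a few compounds, and the source may have more. Where it says the series, first, only, none or still open, it means among the compounds named here.

In a functional assay on K562 cells (Homo sapiens) for antiproliferative activity, with a stated time of 72 h (a lower number here means a stronger inhibitor, a higher number a weaker inhibitor), three compounds have been measured:
- compound 1 `OC[C@H]1O[C@@H](n2cnc3c(NCc4ccccc4F)ncnc32)[C@H](O)[C@@H]1O` gives 33200 nM
- compound 2 `OC[C@H]1O[C@@H](n2cnc3c(NCc4cccc(F)c4)ncnc32)[C@H](O)[C@@H]1O` gives 7600 nM
- compound 3 `OC[C@H]1O[C@@H](n2cnc3c(NCc4ccc(Cl)cc4)ncnc32)[C@H](O)[C@@H]1O` gives 218000 nM

Compound 3 stands at 218000 nM as the weakest inhibitor of the three. Compound 4 `OC[C@H]1O[C@@H](n2cnc3c(NCc4cccc(Br)c4)ncnc32)[C@H](O)[C@@H]1O` carries 3-bromophenyl in place of 4-chlorophenyl on a saturated chain carbon bound to a nitrogen on an aromatic ring. Within the data shown here, no bromine-bearing compound has been measured yet. The closest guide is a 29-fold higher number from compound 2 to compound 3 (1.46 log units; beyond the scatter) on going from 3-fluorophenyl to 4-chlorophenyl, a change that compound 4 roughly undoes. Also relevant is a 6.6-fold higher number from compound 1 to compound 3 (0.82 log units; beyond the scatter) as a second step up to 4-chlorophenyl. A large drop in the number is therefore expected in this assay overall. The estimated change is a 15-fold lower number from compound 3 to compound 4 (1.16 log units; beyond the scatter) in all. For compound 4 the expected value is 15000 nM with an estimated range of 4000 nM to 60000 nM in repeat measurements.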

Compound 4, half-maximal inhibitory concentration: 19700 nM
The estimate for compound 4 lay 1.3-fold (0.12 log units) below the measured number, and the stated range covers the measured number.
By their numbers in this assay, from the lowest: compound 2; then compounds 4 and 1 (each within the scatter of the next); then compound 3.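

In this assay the bromine result shows that a heavier halogen on this ring need not bring the poor result of compound 3 (an 11-fold lower number from compound 3 to compound 4 (1.04 log units; beyond the scatter)). Bromo in place of fluoro on an aromatic carbon, the first halogen swap here with the ring position held, is a much smaller step (a 2.6-fold higher number from compound 2 to compound 4 (0.41 log units; beyond the scatter)), while the step from the 2-fluorophenyl compound lies within the scatter (a 1.7-fold lower number from compound 1 to compound 4 (0.23 log units; within the scatter)). No measured evidence explains these differences.

As far as these compounds go, compound 3 differs from compound 4 in both halogen and ring position, so the two effects remain unseparated. 3-Chlorobenzyl and 4-bromobenzyl would separate them, and a methoxy group on the ring remains open.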